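A few compounds are considered here, and "the series" means these few. Any claim that something is new, unique, unknown or untested is made for them only; others in the source may bear on it.

Three compounds of the series have so far been run in an ADME assay on BCBL1 cells (Homo sapiens) for cytotoxicity, with a stated time of 7 days; on this read-out lower numbers stand for higher toxicity in this test and higher numbers for lower toxicity in this test. Compound 1 `CN(C)c1nc(N)nc2c1ncn2/C=C1/CC1(CO)CO` reports > 20000 nM, which is a limit of the assay and not a number. Compound 3 `CC(C)Nc1nc(N)nc2c1ncn2/C=C1/CC1(CO)CO` likewise reports > 20000 nM, again a limit. Compound 2 `Nc1nc(NCc2ccccc2)c2ncn(/C=C3/CC3(CO)CO)c2n1` gives a number, 19900 nM. The change from compound 1 to compound 2 gives a number no higher from compound 1 to compound 2 (the limit leaves the size open), the change from compound 1 to compound 3 gives a step that the two limits leave unreadable from compound 1 to compound 3, and that from compound 2 to compound 3 gives a number no lower from compound 2 to compound 3 (the limit leaves the size open). Within the data shown here, compound 3 thus sits at the limit of > 20000 nM in this assay, at which 2 of the 3 values shown sit, and the numbers so far show no step that can be read in size.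

Compound 4 `CCCCSc1nc(N)nc2c1ncn2/C=C1/CC1(CO)CO` is not yet measured. It differs from compound 3 by butylsulfanyl in place of isopropylamino on an aromatic carbon. The steps from compound 1 to compound 3 and from compound 2 to compound 3 concern the same position, and both leave their size open, so no step beyond the scatter can be read from them. The step expected is a number no higher from compound 3 to compound 4 (the limit leaves the size open). Compound 4 is therefore estimated at 20000 nM, with a range from 10000 nM to 40000 nM.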

Compound 4, half-maximal cytotoxic concentration: > 20000 nM
Compound 4: no number, only a limit (the forecaster's own chance of this, stated with the estimate: 65%); the middle value lies on the limit itself.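

Compound 4 reports in this assay the value > 20000 nM and this is a limit of the assay, not a number. Among these compounds, the steps from compound 4 to the earlier compounds therefore cannot be read in size, and the change from isopropylamino to butylsulfanyl shows no measurable effect. This position now carries a sulfur-linked chain with 0 hydrogen-bond donors as well as the amino groups, and the series still gathers at one limit: the limit of > 20000 nM in this assay, at which 3 of the 4 values shown sit.

On these data alone, the actual values of compound 1, compound 3 and compound 4 remain unknown, and compound 2, with benzylamino, is still the only one of the four that gives a number. Butylsulfanyl in place of benzylamino gives a number no lower from compound 2 to compound 4 (the limit leaves the size open), and also open is whether a benzylsulfanyl group or a longer chain on the sulfur at this position would give a number within the range of this read-out.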